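Swapping the Octyl Tail for 4-Bromobenzyl on Compound 3

A few compounds are considered here, and "the series" means these few. Any claim that something is new, unique, unknown or untested is made for them only; others in the source may bear on it.

Of the compounds shown here, three of a shared core have been measured in a functional assay on A549 cells (Homo sapiens) for inhibition, read by MTT assay; on this read-out higher numbers stand for weaker inhibition and lower numbers for stronger inhibition. Compound 1 `COc1ccccc1N1CCN(CC(=O)Nc2ccc(C(=O)/C=C/c3cn(Cc4ccc(Br)cc4)nn3)cc2)CC1` gives 34000 nM. Compound 2 `CC(C)(C)OC(=O)N1CCN(CC(=O)Nc2ccc(C(=O)/C=C/c3cn(Cc4ccc(Br)cc4)nn3)cc2)CC1` gives 38400 nM, and the step of a 1.1-fold higher number from compound 1 to compound 2 (0.05 log units; within the scatter) shows that exchanging the group on the ring amine nitrogen left the number essentially where it was. Compound 3 `CCCCCCCCn1cc(/C=C/C(=O)c2ccc(NC(=O)CN3CCN(c4ccc([N+](=O)[O-])cc4)CC3)cc2)nn1` gives 45400 nM, a number that stands beside those of compound 1 and compound 2 within the scatter, so no ordering among the three can be claimed.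

Compound 4 `O=C(CN1CCN(c2ccc([N+](=O)[O-])cc2)CC1)Nc1ccc(C(=O)/C=C/c2cn(Cc3ccc(Br)cc3)nn2)cc1` is reached from compound 3 by the change (4-bromophenyl in place of heptyl on a saturated chain carbon bound to an aromatic nitrogen). For the measured compounds named here, no measured step touches this position: the only measured step, from compound 1 to compound 2, concerns the amine nitrogen, not the chain on the aromatic nitrogen. What is known is that compound 1 and compound 2, which already carry the 4-bromobenzyl group, give numbers within the scatter of compound 3. The expected step of a 1.1-fold lower number from compound 3 to compound 4 (0.05 log units; within the scatter) is therefore no change beyond the scatter. Compound 4 is estimated at 40000 nM, with a range from 16000 nM to 100000 nM.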

Compound 4, half-maximal inhibitory concentration: 45500 nM
Compound 4: middle estimate off by 1.1-fold (0.06 log units), on the low side; the range from low to high includes it.
By their numbers in this assay, from the lowest: compounds 1, 2, 3 and 4 (each within the scatter of the next).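

In this assay, for the compounds shown here, this is the first direct reading at the chain on the aromatic nitrogen: the exchange of octyl for 4-bromobenzyl, with 4-nitrophenyl held on the amine nitrogen in a ring, gives a 1.0-fold higher number from compound 3 to compound 4 (0.00 log units; within the scatter), so the open chain and the aromatic ring cannot be told apart here. With 4-bromobenzyl held, 4-nitrophenyl on that amine nitrogen also cannot be told apart from the two groups seen there earlier, giving a 1.2-fold higher number from compound 2 to compound 4 (0.07 log units; within the scatter) and a 1.3-fold higher number from compound 1 to compound 4 (0.13 log units; within the scatter). No supporting data bear on these results.

The compounds shown leave open whether an amine or a carboxylic acid in place of octyl or 4-bromobenzyl would give a number outside the scatter. As far as these compounds go, it also remains open whether a much shorter chain, such as methyl, at this place would do so.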